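Series notes: carbonyl substituent change at compound 4

The source may hold more compounds than are shown below. What is called first, only, known or untested is meant among the compounds shown, and "the series" means these compounds.

Three compounds of the series have numbers in a functional assay on 786-0 cells (Homo sapiens) for inhibition, read by sulforhodamine B assay, with a stated time of 48 h; a higher number here means a weaker inhibitor of growth, a lower number a stronger inhibitor of growth. Compound 1 `O=C(Nc1cccc(-n2cc(-c3ccncc3)c(-c3ccc(Cl)c(O)c3)n2)c1)Nc1cccc(C(F)(F)F)c1` gives 4690 nM. Compound 2 `COc1cc(-c2nn(-c3cccc(NC(=O)Nc4cc(C(F)(F)F)cc(C(F)(F)F)c4)c3)cc2-c2ccncc2)ccc1Cl` gives 950 nM. Compound 3 `COc1cc(-c2nn(-c3cccc(NC(=O)Nc4cccc(C(F)(F)F)c4)c3)cc2-c2ccncc2)ccc1Cl` gives 1280 nM. Two single-point steps connect them: a 3.7-fold lower number from compound 1 to compound 3 (0.56 log units; beyond the scatter), and a 1.3-fold higher number from compound 2 to compound 3 (0.13 log units; within the scatter). Compound 3 therefore stands second highest of the three numbers, close to compound 2 and well apart from compound 1.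

Compound 4 `COc1cc(-c2nn(-c3cccc(NC(=O)c4ccccc4)c3)cc2-c2ccncc2)ccc1Cl` differs from compound 3 in one place: phenyl in place of (3-(trifluoromethyl)phenyl)amino on a carbonyl carbon. Neither measured step bears directly on this change. The step from compound 2 to compound 3 removed one trifluoromethyl on an aromatic carbon and stayed within the scatter, which speaks against a large effect from the trifluoromethyl alone; nothing in the series, however, tests the loss of a hydrogen-bond donor on the carbonyl carbon, so the direction of the step is not covered by the data. The step in this assay from compound 3 to compound 4 is expected to be a 2.5-fold higher number from compound 3 to compound 4 (0.40 log units; beyond the scatter), with a wide range to reflect the untested change. Compound 4 is estimated at 3200 nM, with a range from 700 nM to 15000 nM.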

Compound 4, concentration for 50% growth inhibition: 1520 nM
The estimate for compound 4 lay 2.1-fold (0.32 log units) above the measured number; the measured number falls inside the stated range.
By their numbers in this assay, from the lowest: compounds 2, 3 and 4 (each within the scatter of the next); then compound 1.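

In this assay phenyl in place of (3-(trifluoromethyl)phenyl)amino on a carbonyl carbon gives a 1.2-fold higher number from compound 3 to compound 4 (0.07 log units; within the scatter) and so leaves the number within the scatter. This is the first change shown on the carbonyl carbon itself: the amide-type nitrogen stays, while the entering phenyl has fewer heavy atoms than the leaving group and, unlike it, no hydrogen-bond donor, and neither the loss of the trifluoromethyl nor that of the donor shifts the number beyond the scatter when the two go together. No measured evidence accounts for this result.

The compounds shown leave open how much each part of the leaving group contributes alone, since the amino link and the trifluoromethyl leave in a single step and their separate contributions may differ from the combined one. They also leave open whether this carbonyl carbon accepts groups other than an aromatic ring, such as a short alkyl chain, a morpholine or a carboxylic acid-bearing chain, with the number still staying within the scatter of compound 3.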